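The compounds below may be only part of what the source reports. "The series", "measured", "known", "first", "only" and "open" are said of these compounds alone.

In a functional assay on SK-MEL cells (Homo sapiens) for cytotoxicity (on this read-out lower numbers stand for stronger inhibition and higher numbers for weaker inhibition), compound 1 (`COc1ccc(CO[C@H]2CC[C@]3(C)C[C@H](Cc4ccc(C(=O)O)cc4)CCC3C2(C)C)cc1`) gives 200000 nM and compound 2 (`CC1(C)C2CC[C@@H](Cc3ccc(C(=O)O)cc3)C[C@@]2(C)CC[C@@H]1O`) gives 378000 nM while compound 3 (`CC1(C)C2CCC[C@H](/C=C/c3ccc(C(=O)O)cc3)[C@@]2(C)CC[C@@H]1O`) gives 380000 nM and these numbers all sit within the scatter of one another, so compound 1 holds no distinct rank. Compound 4 (`COc1ccc(CO[C@H]2CC[C@]3(C)C[C@H](Cc4cccc(C(=O)O)c4)CCC3C2(C)C)cc1`) has 3-carboxyphenyl in place of 4-carboxyphenyl on a saturated chain carbon bound to a saturated ring carbon. Within the data shown here, the only single-place step measured (a 1.9-fold higher number from compound 1 to compound 2 (0.28 log units; within the scatter)) lies at another place and within the scatter, and no measured pair tests this change. In this assay no step beyond the scatter is therefore expected. The expected step is small (a 1.3-fold higher number from compound 1 to compound 4 (0.10 log units; within the scatter)). Compound 4 is expected at 250000 nM (estimated range 100000 nM to 500000 nM).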

Compound 4, half-maximal inhibitory concentration: 180000 nM
For compound 4 the middle estimate is 1.4-fold (0.14 log units) above the measured one; the measured number falls inside the stated range.
By their numbers in this assay, from the lowest: compounds 4, 1, 2 and 3 (each within the scatter of the next, the first and the last beyond it).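

With 3-carboxyphenyl in place of 4-carboxyphenyl on a saturated chain carbon bound to a saturated ring carbon, this assay gives a 1.1-fold lower number from compound 1 to compound 4 (0.05 log units; within the scatter). Among these compounds, this pair is the first direct test at this place, and on the shared core of compound 1 and compound 4 the read-out does not separate the two carboxyphenyl isomers. No available evidence bears on this result.

Still open, as far as these compounds go, is whether a methyl ester or a primary amide in place of the carboxylic acid would give a step beyond the scatter. From the compounds shown here alone, a longer chain between the saturated ring carbon and the 3-carboxyphenyl group also remains untested here.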